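Series notes: amino in place of pyrrolidin-1-yl

This account rests on a few compounds, and the source may have more. Where it says the series, first, only, none or still open, it means among the compounds named here.

Three compounds of this series have a number in an assay on isolated protein for binding affinity to Leucine-rich repeat serine/threonine-protein kinase 2 (Homo sapiens), read by TR-FRET and LanthaScreen, with a stated time of 2 h; a higher number here means a weaker inhibitor, a lower number a stronger inhibitor. Compound 1 `Cn1c(N2CCCC2)c(C#N)c2c(N)ncnc21` gives 41 nM in this assay. Compound 2 `Cn1c(-c2cccc(F)c2F)c(C#N)c2c(N)ncnc21` gives 14 nM in this assay, and compound 3 `Cc1cn(C)nc1Nc1cc2c(c(N)n1)c(C#N)c(N1CCC[C@H]1C)n2C` gives 63 nM in this assay.

Among these three numbers compound 1 stands second highest. Its nearest neighbour is compound 3, whose number is within the usual scatter of that of compound 1, so no order between the two is claimed. Compound 2 lies furthest from compound 1, with a lower number, and this gap is beyond the scatter.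

The next compound, compound 4 `Cn1c(N)c(C#N)c2c(N)ncnc21`, is not yet measured in this assay. It differs from compound 1 in one place: amino in place of pyrrolidin-1-yl on an aromatic carbon

Among the compounds with values here, no measured pair isolates this change, so its size in this assay is not known from the data. The expectation is a moderate step towards a higher number, beyond the scatter, and the step from compound 1 to compound 4 is estimated as a 3.7-fold higher number from compound 1 to compound 4 (0.56 log units; beyond the scatter). For compound 4 the estimated inhibition constant in this assay is 150 nM, with a range from 40 nM to 600 nM.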

Compound 4, inhibition constant: 346 nM
For compound 4 the middle estimate is 2.3-fold (0.36 log units) below the measured one, within the range that was stated.
By their numbers in this assay, from the lowest: compound 2; then compounds 1 and 3 (each within the scatter of the next); then compound 4.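

In this assay, within the data shown here, amino in place of pyrrolidin-1-yl on this aromatic carbon gives an 8.4-fold higher number from compound 1 to compound 4 (0.93 log units; beyond the scatter), the first step that isolates a change at this position. The position is therefore not indifferent to its substituent: losing the five-membered non-aromatic ring and its 5 heavy atoms, and gaining a hydrogen-bond donor, moves the number beyond the scatter, although compound 4 still gives a measurable 346 nM with only the amino group in place. Nothing available explains the size of this step.

Going by these compounds, whether the step follows the loss of the ring, the loss of its carbon atoms or the entry of the amino hydrogens stays open; dimethylamino, with no ring and no amino hydrogen, and methylamino, with one amino hydrogen, would help to separate these, while a piperidine ring would test a larger ring at the same carbon. The same change on the core of compound 3 has no counterpart among the compounds shown, so whether the step carries over to that core is unknown.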